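Cyclohexylmethoxy in Place of Difluorophenyl: an Expected Loss

This account rests on a few compounds, and the source may have more. Where it says the series, first, only, none or still open, it means among the compounds named here.

Among the measured compounds shown here, in a functional assay on HEK293 cells for negative allosteric modulation of metabotropic glutamate receptor 5 (Homo sapiens), read by FLIPR and calcium flux (a higher number here means a weaker inhibitor, a lower number a stronger inhibitor), compound 2 `Cc1cccc(NC(=O)c2nn(C)c(-c3ccc(F)cc3F)c2C)n1` gives 3.7 nM, the only plain number among the two values shown. Compound 1 `Cc1cccc(NC(=O)c2c3c(nn2C)CCCC3)n1` reaches only a limit of the assay, > 1000 nM, which is the limit of > 1000 nM in this assay, at which 1 of the 2 values shown sits. Compound 3 `Cc1cccc(NC(=O)c2nn(C)c(OCC3CCCCC3)c2C)n1` differs from compound 2 by cyclohexylmethoxy in place of 2,4-difluorophenyl on an aromatic carbon. For the measured compounds named here, no measured step of this kind is available, so the expectation rests on the structural change alone: a shift toward weaker inhibition, beyond the usual scatter, is expected, a 16-fold higher number from compound 2 to compound 3 (1.21 log units; beyond the scatter). Compound 3 is therefore estimated at 60 nM, with a range from 8 nM to 600 nM.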

Compound 3, half-maximal inhibitory concentration: 1300 nM
The estimate for compound 3 lay 22-fold (1.34 log units) below the measured number; the measured number lies above the stated range.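

Placing cyclohexylmethoxy in place of 2,4-difluorophenyl on this aromatic carbon gives a 350-fold higher number from compound 2 to compound 3 (2.55 log units; beyond the scatter) in this assay. The two groups have the same count of 8 heavy atoms, so this position distinguishes between groups of equal heavy-atom count, not only between groups of different size. Nothing in the data shown gives a reason for the loss. The step changes the ring from aromatic to non-aromatic and adds an oxygen at once, leaving the share of each open. Directly attached cyclohexyl or phenylmethoxy on the same carbon would separate the two.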